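Alkyl swap on the amine nitrogen: cyclopropyl to tert-butyl

The compounds below may be only part of what the source reports. "The series", "measured", "known", "first", "only" and "open" are said of these compounds alone.

Measured so far in a functional assay on PC-3 cells (Homo sapiens) for cytotoxicity, read by MTT assay, with a stated time of 48 h; on this read-out higher numbers stand for weaker inhibition and lower numbers for stronger inhibition:
compound 1 `Cc1ccc(S(=O)(=O)N2N=C(c3cc4ccccc4oc3=O)CC2c2ccccc2)cc1` gives 48600 nM;
compound 2 `CCNCC(=O)N1N=C(c2cc3ccccc3oc2=O)CC1c1ccccc1` gives 5580 nM;
compound 3 `O=C(CNC1CC1)N1N=C(c2cc3ccccc3oc2=O)CC1c1ccccc1` gives 28500 nM.

Compound 3 stands second highest of the three numbers, separated from compound 1 by a 1.7-fold lower number from compound 1 to compound 3 (0.23 log units; within the scatter) and from compound 2 by a 5.1-fold higher number from compound 2 to compound 3 (0.71 log units; beyond the scatter). The new compound 4 `CC(C)(C)NCC(=O)N1N=C(c2cc3ccccc3oc2=O)CC1c1ccccc1` keeps the shared core of compound 3 and differs only by tert-butyl in place of cyclopropyl on an amine nitrogen. For the measured compounds named here, only one measured step touches the same place: the change from ethyl to cyclopropyl on the amine nitrogen, a 5.1-fold higher number from compound 2 to compound 3 (0.71 log units; beyond the scatter), which raised the number beyond the scatter. The steps of an 8.7-fold lower number from compound 1 to compound 2 (0.94 log units; beyond the scatter) and a 1.7-fold lower number from compound 1 to compound 3 (0.23 log units; within the scatter) concern the group on the ring nitrogen and say nothing direct about the alkyl on the amine. Going by the values given here, no measured pair shows tert-butyl at this site, so the direction is open; in this assay compound 4 is expected to move by a 1.1-fold lower number from compound 3 to compound 4 (0.06 log units; within the scatter), a step not clearly beyond the scatter. The estimate for compound 4 is 25000 nM, with a range from 8000 nM to 80000 nM.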

Compound 4, half-maximal inhibitory concentration: 16400 nM
Compound 4: middle estimate off by 1.5-fold (0.18 log units), on the high side, within the range that was stated.
By their numbers in this assay, from the lowest: compound 2; then compounds 4, 3 and 1 (each within the scatter of the next, the first and the last beyond it).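

In this assay, tert-butyl on the amine nitrogen cannot be told apart from cyclopropyl (a 1.7-fold lower number from compound 3 to compound 4 (0.24 log units; within the scatter)), although it has no ring and one more carbon, so that ring is not needed for a number in this range. Ethyl stays separate from tert-butyl (a 2.9-fold higher number from compound 2 to compound 4 (0.47 log units; beyond the scatter)), which leaves compound 2 alone, beyond the scatter of both compound 3 and compound 4, among the three alkyl groups. Compound 4 also stands apart from the sulfonyl compound (a 3.0-fold lower number from compound 1 to compound 4 (0.47 log units; beyond the scatter)), as compound 2 does and compound 3 does not, though compounds 3 and 4 remain within the scatter of each other, and no evidence on hand bears on any of these differences.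

Open, on these data alone, is whether a longer chain such as n-butyl on the amine nitrogen stays with compound 2 or joins compounds 3 and 4. A free primary amine or a piperidine at the same place would show whether the ethyl result is more than a single point.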